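Dihydrobenzofuran for Fluorophenyl on a Shared Aryl Ether Core

The source may report more compounds than this note shows. Statements on the series, on what has been measured and on what is new or still open speak of the compounds shown alone.

Measured compounds:
compound 1 `Cn1c(COc2cccc(C(=O)O)c2)nc2ccc(Oc3ccc(Cl)c(F)c3)nc21` — 2.2
compound 2 `Cn1c(COc2cccc(C(=O)O)c2)nc2ccc(Oc3ccc(F)cc3)nc21` — 1.5
compound 3 `Cc1cc(C)cc(Oc2ccc3nc(COc4cccc(C(=O)O)c4)n(C)c3n2)c1` — 2.3

These values come from a physicochemical assay for lipophilicity, read by LC-MS, in phosphate buffer, measured as octanol-water partition, with a stated time of 30 min, at pH 7.4, tested at 200 mM; on this read-out lower numbers stand for lower lipophilicity and higher numbers for higher lipophilicity. Compound 2 gives the lowest of the three numbers: compound 1 lies nearer, compound 3 further away. The step of a number 0.70 log units lower from compound 1 to compound 2 (beyond the scatter) and the step of a number 0.80 log units higher from compound 2 to compound 3 (beyond the scatter) both changed the group on the aryl ether oxygen, each a modest move. The unmeasured compound 4 `Cn1c(COc2cccc(C(=O)O)c2)nc2ccc(Oc3ccc4c(c3)OCC4)nc21` differs from compound 2 in that place: a group of 9 heavy atoms (8 carbon, 1 oxygen; one five-membered non-aromatic ring with 1 hetero atom, one six-membered aromatic ring of carbon only) in place of a group of 7 heavy atoms (6 carbon, 1 fluorine; one six-membered aromatic ring of carbon only), on an oxygen on an aromatic ring. Going by the values given here, no measured step introduces this bicyclic group, so the neighbouring steps only bound the size of the move. Compound 4 is therefore expected to stay near compound 2, with a step of a number 0.10 log units lower from compound 2 to compound 4 (within the scatter) that may fall within the scatter, and an estimated 1.4 in the range 0.9 to 1.9.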

Compound 4, distribution coefficient: 1.4
For compound 4 middle estimate and measured number coincide at the digits printed, and the stated range covers the measured number.
By their numbers in this assay, from the lowest: compounds 4 and 2 (each within the scatter of the next); then compounds 1 and 3 (each within the scatter of the next).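

In this assay the bicyclic group on the oxygen on an aromatic ring reads as 4-fluorophenyl does, with a number 0.10 log units lower from compound 2 to compound 4 (within the scatter) even though it is the largest group of the four by heavy atoms. It stands apart from the other two groups, with a number 0.90 log units lower from compound 3 to compound 4 (beyond the scatter) and with a number 0.80 log units lower from compound 1 to compound 4 (beyond the scatter) as well. Across these compounds, the number therefore does not follow heavy-atom count.

No measurement shown explains these steps. Also open, from the compounds shown here alone, is how an aromatic group carrying an amine would read on this oxygen.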